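The compounds below may be only part of what the source reports. "The series", "measured", "known", "first", "only" and "open" are said of these compounds alone.

Measured so far in a functional assay on OVCAR-3 cells (Homo sapiens) for antiproliferative activity, read by sulforhodamine B assay, with a stated time of 72 h; on this read-out lower numbers stand for stronger inhibition and higher numbers for weaker inhibition:
- compound 1 `Cc1cc(C)nc(NS(=O)(=O)c2ccc(Nc3nncc4ccccc34)cc2)n1` gives 3.4 nM
- compound 2 `O=S(=O)(Nc1ccccn1)c1ccc(Nc2nncc3ccccc23)cc1` gives 83 nM

Compound 2 holds the higher of the two numbers. Compound 3 `Cc1cc(NS(=O)(=O)c2ccc(Nc3nncc4ccccc34)cc2)no1` is still unmeasured and carries 5-methyl-1,2-oxazol-3-yl in place of pyridin-2-yl on a sulfonamide nitrogen. Going by the values given here, only one measured step bears on this change, a large one at the same place: a 24-fold higher number from compound 1 to compound 2 (1.39 log units; beyond the scatter). With so little to go on, a moderate move towards a lower number is expected in this assay, though the direction remains uncertain. The expected step is a 2.8-fold lower number from compound 2 to compound 3 (0.44 log units; beyond the scatter). For compound 3 the estimated value is 30 nM, with an expected range from 6 nM to 150 nM.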

Compound 3, half-maximal inhibitory concentration: 54 nM
The estimate for compound 3 lay 1.8-fold (0.26 log units) below the measured number; the range from low to high includes it.
By their numbers in this assay, from the lowest: compound 1; then compounds 3 and 2 (each within the scatter of the next).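

The swap from a six-membered to a five-membered aromatic ring at the sulfonamide nitrogen leaves the number within the scatter (a 1.5-fold lower number from compound 2 to compound 3 (0.19 log units; within the scatter)), so these two groups cannot be told apart here. The gap to the 4,6-dimethylpyrimidin-2-yl group of compound 1 persists with this second group (a 16-fold higher number from compound 1 to compound 3 (1.20 log units; beyond the scatter)), and compound 1 keeps the lowest number of the three. Nothing shown here explains this. From the compounds shown here alone, whether the low number of compound 1 would survive with an unsubstituted pyrimidin-2-yl group, without its two methyl groups, remains open.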